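Anilino-thiazolyl chalcones: cytotoxicity at the assay limit

A few compounds are considered here, and "the series" means these few. Any claim that something is new, unique, unknown or untested is made for them only; others in the source may bear on it.

Measured compounds:
- compound 1 `Cc1ccccc1Nc1nc(C)c(C(=O)/C=C/c2ccccc2)s1` gives > 25000 nM in a functional assay on PC-3 cells (Homo sapiens) for cytotoxicity, read by MTT assay; a higher number here means a weaker inhibitor, a lower number a stronger inhibitor; this is a limit of the assay.
- compound 2 `COc1cccc(/C=C/C(=O)c2sc(Nc3ccccc3C)nc2C)c1` gives > 25000 nM; again a limit.
- compound 3 `COc1cccc(/C=C/C(=O)c2sc(Nc3ccc(C)cc3)nc2C)c1` gives > 25000 nM; again a limit.

All three values sit at the same limit (the limit of > 25000 nM in this assay, at which 3 of the 3 values shown sit), so no ranking among them is possible. The change from compound 2 to compound 1 is hydrogen in place of methoxy on an aromatic carbon, and its step is a step that the two limits leave unreadable from compound 2 to compound 1. The two cores differ by 4-methylphenyl in place of 2-methylphenyl on a nitrogen on an aromatic ring, with step that the two limits leave unreadable from compound 2 to compound 3.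

Compound 4 `Cc1ccc(Nc2nc(C)c(C(=O)/C=C/c3ccccc3)s2)cc1` is not yet measured. It differs from compound 3 by hydrogen in place of methoxy on an aromatic carbon, the same change as from compound 2 to compound 1, at the same place. Since every measured value is a limit, the step from compound 3 to compound 4 is expected to be a step that the limit leaves unreadable from compound 3 to compound 4, resting on the limit values of compounds 1, 2 and 3. Compound 4 is therefore estimated at 30000 nM, most likely reported as a limit again.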

Compound 4, half-maximal inhibitory concentration: > 25000 nM
Compound 4 ended at the assay's limit; the forecaster's own chance of this, stated with the estimate: 80%; the middle value is on the limit's open side.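

No step can be read from compound 3 or from compound 1 to compound 4, since all the values are limits of the assay: the limit of > 25000 nM in this assay, at which 4 of the 4 values shown sit.

The compounds shown leave open whether either change, methoxy to hydrogen or 2-methylphenyl to 4-methylphenyl, alters the result in this assay at all.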